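From Compound 3 to Compound 4: a Halophenyl Swap

The source may hold more compounds than are shown below. What is called first, only, known or untested is meant among the compounds shown, and "the series" means these compounds.

Three compounds have been measured in a functional assay (muscle tissue) with Cavia porcellus as the target; a lower number here means that less compound is needed, a higher number that more compound is needed for the effect:

Compound 1, `COC(=O)C1=C(C)N=C(C)/C(=C(\O)OC)C1c1ccc(I)cc1`, gives 22900 nM.
Compound 2, `COC(=O)C1=C(C)N=C(C)/C(=C(\O)OC)C1c1ccccc1I`, gives 46.8 nM.
Compound 3, `COC(=O)C1=C(C)N=C(C)/C(=C(\O)OC)C1c1ccccc1Br`, gives 7.59 nM.

Compound 3 stands lowest of the three numbers; its nearest neighbour is compound 2, separated by a 6.2-fold lower number from compound 2 to compound 3 (0.79 log units; beyond the scatter), and the furthest is compound 1, separated by a 3000-fold lower number from compound 1 to compound 3 (3.48 log units; beyond the scatter). Compound 4, `COC(=O)C1=C(C)N=C(C)/C(=C(\O)OC)C1c1cccc(F)c1`, differs from compound 3 in one place: 3-fluorophenyl in place of 2-bromophenyl on a saturated ring carbon.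

Two kinds of measured step bear on this change, though neither covers it fully. Exchanging 4-iodophenyl for 2-iodophenyl or for 2-bromophenyl gave a 490-fold lower number from compound 1 to compound 2 (2.69 log units; beyond the scatter) and a 3000-fold lower number from compound 1 to compound 3 (3.48 log units; beyond the scatter), both large, while exchanging iodo for bromo on the aromatic carbon gave a 6.2-fold lower number from compound 2 to compound 3 (0.79 log units; beyond the scatter), a modest step. Among the measured compounds shown here, no measured compound carries a 3-fluorophenyl or any fluorine, so the expectation for compound 4 rests on the observation that the two lowest numbers belong to compound 2 and compound 3, both of which keep a halogen where compound 4 does not. A higher number, a 16-fold higher number from compound 3 to compound 4 (1.20 log units; beyond the scatter), is therefore expected for compound 4, with considerable uncertainty. Compound 4 is estimated at 120 nM, within a range from 15 nM to 1000 nM.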

Compound 4, half-maximal effective concentration: 20.9 nM
Beside the measured number, compound 4's estimate is 5.7-fold (0.76 log units) above it; measured number inside the range.
By their numbers in this assay, from the lowest: compound 3; then compound 4; then compound 2; then compound 1.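

In this assay, among the compounds shown here, the earlier compounds tied the low numbers to the two groups 2-iodophenyl and 2-bromophenyl, with 4-iodophenyl far higher, but 3-fluorophenyl on the same saturated ring carbon shows that a low number does not require either of them. The swap from 2-bromophenyl costs little, as the modest step shows (a 2.8-fold higher number from compound 3 to compound 4 (0.44 log units; beyond the scatter)), and compound 4 even stands on the lower side of the 2-iodophenyl compound (a 2.2-fold lower number from compound 2 to compound 4 (0.35 log units; beyond the scatter)), while its distance from the 4-iodophenyl compound is large (a 1100-fold lower number from compound 1 to compound 4 (3.04 log units; beyond the scatter)). The saturated ring carbon therefore accepts more than one kind of halophenyl group with only modest shifts, although nothing measured here explains the result.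

Since the halogen and its place on the phenyl ring differ together in every comparison, the compounds shown leave the share of each undivided, and 2-fluorophenyl, 4-fluorophenyl or 3-iodophenyl would be needed to separate them. From the compounds shown here alone, it also stays open whether a plain phenyl, or a phenyl carrying an amine or a carboxylic acid, would keep a number this low.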